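Compound 2 Gives Up Its Diethylcarbamoyl Group

This account rests on a few compounds, and the source may have more. Where it says the series, first, only, none or still open, it means among the compounds named here.

Compound 1 `COc1cc2ncnc(-n3nc(-c4ccccn4)nc3N)c2cc1OCCCN1CC(C)OC(C)C1`: 8000 nM
Compound 2 `CCN(CC)C(=O)COc1cc2c(-n3nc(-c4ccccn4)nc3N)ncnc2cc1OC`: 42000 nM

Going by the values given here, in a physicochemical assay for solubility, in phosphate buffer, with a stated time of 18 h, at pH 7.4 (on this read-out higher numbers stand for higher solubility and lower numbers for lower solubility), compound 2 stands highest of the two measured compounds at 42000 nM, and the only other number is that of compound 1 at 8000 nM. The next compound to be read is compound 3 `COc1cc2ncnc(-n3nc(-c4ccccn4)nc3N)c2cc1OCCCNC(=O)OC(C)(C)C`. The change from compound 2 is 2-((tert-butoxycarbonyl)amino)ethyl in place of diethylcarbamoyl on a saturated chain carbon bound to an oxygen on an aromatic ring.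

Among the compounds with values here, only one measured step bears on this change, and it falls at the same place: a 5.3-fold higher number from compound 1 to compound 2 (0.72 log units; beyond the scatter). That step is modest but beyond the scatter, and it is the step that brought in the diethylcarbamoyl group. Compound 3 loses that group again, so a move back to a lower number of similar size is expected, although a single step is thin support and the entering group has not been measured before. The expected step is a 6.0-fold lower number from compound 2 to compound 3 (0.78 log units; beyond the scatter). Compound 3 is estimated at 7000 nM, with an expected range from 1500 nM to 30000 nM.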

Compound 3, solubility: 2000 nM
The estimate for compound 3 lay 3.5-fold (0.54 log units) above the measured number, within the range that was stated.
By their numbers in this assay, from the lowest: compound 3; then compound 1; then compound 2.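

Replacing diethylcarbamoyl with 2-((tert-butoxycarbonyl)amino)ethyl in this assay gives a 21-fold lower number from compound 2 to compound 3 (1.32 log units; beyond the scatter) at this position on a saturated chain carbon bound to an oxygen on an aromatic ring, a large step that takes the number past that of compound 1 and leaves compound 3 lowest of the three. The earlier pair had shown only that the two groups compared there could differ by a modest step; compound 3 adds that the end of the chain matters by itself, since (tert-butoxycarbonyl)amino in place of 2,6-dimethylmorpholin-4-yl, on a saturated chain carbon, three bonds along the chain from an oxygen on an aromatic ring, gives a 4.0-fold lower number from compound 1 to compound 3 (0.60 log units; beyond the scatter) in the same read-out. Nothing at hand explains why the number moves in either step.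

With so few compounds, the effect of the chain end cannot be separated from that of the linking group that diethylcarbamoyl brings. It remains open where a free primary amine or a carboxylic acid at the end of the propoxy chain would fall among these numbers, and whether a longer chain carrying 2,6-dimethylmorpholin-4-yl would hold the number of compound 1.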